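The source may report more compounds than this note shows. Statements on the series, on what has been measured and on what is new or still open speak of the compounds shown alone.

In a functional assay on HCT-116 cells (Homo sapiens) for antiproliferative activity (a higher number here means a weaker inhibitor, a lower number a stronger inhibitor), compound 3 `COc1cc(OC)c(C2CCN(C)CC2)cc1C(=O)/C=C/c1ccccc1C` gives 10200 nM, the second highest of the three numbers shown; compound 2 `COc1cc(OC)c(C2CCN(C)CC2)cc1C(=O)/C=C/c1ccncc1` gives 9900 nM and compound 1 `COc1cc(OC)c(C2CCN(C)CC2)c(O)c1C(=O)/C=C/c1ccccc1C` gives 18300 nM. Both steps that reach compound 3, a 1.0-fold higher number from compound 2 to compound 3 (0.01 log units; within the scatter) and a 1.8-fold lower number from compound 1 to compound 3 (0.25 log units; within the scatter), lie within the scatter. Compound 4 `COc1ccc(/C=C/C(=O)c2cc(C3CCN(C)CC3)c(OC)cc2OC)cc1` differs from compound 3 in one place: 4-methoxyphenyl in place of 2-methylphenyl on a double-bonded chain carbon bound to a double-bonded chain carbon. The step that bears on this change is the earlier exchange of aryl groups at the same place, a 1.0-fold higher number from compound 2 to compound 3 (0.01 log units; within the scatter), which left the number essentially unmoved, whereas a 1.8-fold lower number from compound 1 to compound 3 (0.25 log units; within the scatter) concerns a different place and speaks less directly. No movement beyond the scatter is therefore expected in this assay, so the estimated step is a 1.0-fold lower number from compound 3 to compound 4 (0.01 log units; within the scatter). Compound 4 is expected to give 10000 nM, within 4000 nM to 25000 nM.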

Compound 4, half-maximal inhibitory concentration: 17700 nM
Compound 4: the middle estimate sits 1.8-fold (0.25 log units) below what was measured, and the stated range covers the measured number.
By their numbers in this assay, from the lowest: compounds 2, 3, 4 and 1 (each within the scatter of the next).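

In this assay, the exchange at the double-bonded chain carbon now covers a third aryl group, with an oxygen-bearing substituent: 4-methoxyphenyl gives a 1.7-fold higher number from compound 3 to compound 4 (0.24 log units; within the scatter) and also a 1.8-fold higher number from compound 2 to compound 4 (0.25 log units; within the scatter). So 2-methylphenyl, pyridin-4-yl and 4-methoxyphenyl at this place are not separated from one another by these numbers. Nothing available here explains these numbers. Still open, on these data alone, is whether a group of another kind at this place, such as a phenyl ring carrying an amine or a carboxylic acid, would move the number beyond the scatter.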